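Swapping the amide substituent in a quinoline ether series

The source may hold more compounds than are shown below. What is called first, only, known or untested is meant among the compounds shown, and "the series" means these compounds.

Of the compounds shown here, three share one core and have been measured in a physicochemical assay for lipophilicity, read by HPLC, in phosphate buffer, measured as chromatographic lipophilicity, at pH 7.4; a lower number here means a more polar compound, a higher number a more lipophilic compound. Compound 1 `CCC(Oc1cc(C)nc2ccc(OC)cc12)C(=O)Nc1cc(C)cc(C)c1` gives 6.28, compound 3 `COc1ccc2nc(C)cc(OCCNc3cc(C)cc(C)c3)c2c1` gives 6.93, and compound 2 `COc1ccc2nc(C)cc(OCC(=O)NCc3cc(C)cc(C)c3)c2c1` gives 5.25. Compound 2 thus stands lowest of the three: compound 1 lies a step higher that is beyond the scatter, and compound 3 lies further above it, again beyond the scatter.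

Compound 4 `COc1ccc2nc(C)cc(OCC(=O)Nc3ccccn3)c2c1` has not yet been measured in this assay. It differs from compound 2 in one place: pyridin-2-yl in place of 3,5-dimethylbenzyl on an amide-type nitrogen. Among the compounds with values here, no measured pair in this set shows this exact change, so what it does can only be expected, not read off. A group with nine carbon atoms and no acceptors leaves, and a smaller group with a hetero atom and one acceptor enters, which is expected to push the number down by more than the scatter, a step of about a number 1.75 log units lower from compound 2 to compound 4 (beyond the scatter) in this assay. On that basis compound 4 is estimated at 3.5, with a likely range from 2.8 to 4.3.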

Compound 4, distribution coefficient: 3.49
Compound 4: the middle estimate sits 0.01 log units above what was measured; the range from low to high includes it.
By their numbers in this assay, from the lowest: compound 4; then compound 2; then compound 1; then compound 3.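

The set now holds its first pair that differs in one place, and it shows that the group on the amide-type nitrogen has a strong hold on the reading in this assay: pyridin-2-yl in place of 3,5-dimethylbenzyl gives a number 1.76 log units lower from compound 2 to compound 4 (beyond the scatter), a large step. This one change bundles two things, since a ring of carbon only gives way to a ring with a hetero atom, and the group shrinks from 9 heavy atoms to 6. Nothing measured here gives a reason for the size of this step.

Which part of the change carries the step stays open. A plain phenyl or an unsubstituted benzyl on the same amide-type nitrogen would help to separate the effect of the ring nitrogen from that of the carbon atoms that leave.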